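Biaryl extension of the benzamide series: cytotoxicity notes

A few compounds are considered here, and "the series" means these few. Any claim that something is new, unique, unknown or untested is made for them only; others in the source may bear on it.

Measured compounds:
compound 1 `CC(C)N(Cc1cccc(OCCCCCC(=O)O)c1)C(=O)c1ccccc1` — > 26000 nM
compound 2 `CC(C)N(Cc1cccc(OCCCCCC(=O)O)c1)C(=O)c1ccc(-c2ccc3cc[nH]c3c2)cc1` — > 26000 nM

Both values come from an ADME assay on Raji cells (Homo sapiens) for cytotoxicity, read by CellTiter-Glo and resazurin assay, with a stated time of 72 h (a higher number here means that more compound is needed for the effect, a lower number that less compound is needed), and both are limits of the assay rather than numbers. In this assay compound 1 gives > 26000 nM, a limit. Compound 2 likewise reaches only the limit > 26000 nM. The step that the two limits leave unreadable from compound 1 to compound 2 is therefore unreadable; both values sit at the limit of > 26000 nM in this assay, at which 2 of the 2 values shown sit. Compound 1 thus stands at the assay limit with no finer placement on the numbers shown.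

Compound 3 `COc1cc(OC)cc(-c2ccc(C(=O)N(Cc3cccc(OCCCCCC(=O)O)c3)C(C)C)cc2)c1` differs from compound 1 by 3,5-dimethoxyphenyl in place of hydrogen on an aromatic carbon. For the measured compounds named here, the only measured step that bears on this change is a step that the two limits leave unreadable from compound 1 to compound 2, which also introduces an aromatic group on an aromatic carbon of the shared core and is itself not readable. No size or direction of step can be expected in this assay beyond the scatter, and the most likely outcome is again a reported limit. For compound 3 the expected value in this assay is 35000 nM, with an estimated range of 12000 nM to 120000 nM. The step that the limit leaves unreadable from compound 1 to compound 3 is expected to be negligible on this reading.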

Compound 3, half-maximal effective concentration: > 26000 nM
Compound 3 gave a limit, no number; the forecaster's own chance of this, stated with the estimate: 80%; the middle value is on the limit's open side.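

Compound 3 in this assay gives > 26000 nM, which is again a limit, so no step among compound 1, compound 2 and compound 3 can be read: the limit of > 26000 nM in this assay, at which 3 of the 3 values shown sit.

The compounds shown leave open how far each lies from that limit, and whether 1H-indol-6-yl and 3,5-dimethoxyphenyl differ at all in this assay.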